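A few compounds are considered here, and "the series" means these few. Any claim that something is new, unique, unknown or untested is made for them only; others in the source may bear on it.

In an ADME assay on MT4 cells (Homo sapiens) for cytotoxicity, read by MTT assay (on this read-out lower numbers stand for higher toxicity in this test and higher numbers for lower toxicity in this test), compound 1 `O=C1c2ccccc2C(=O)N1CCOC(=S)N(C(=O)c1ccc([N+](=O)[O-])cc1)c1ccc(Cl)cc1` reads > 100000 nM, which is a limit of the assay and not a number. Among the measured compounds shown here, compound 2 `O=C1c2ccccc2C(=O)N1CCOC(=S)N(C(=O)c1cc(F)ccc1F)c1ccc(Cl)cc1` gives 54000 nM, the only true number so far, so it can be ranked against no other measured value.

Compound 3 `O=C1c2ccccc2C(=O)N1CCOC(=S)N(C(=O)c1ccc(Cl)c(Cl)c1)c1ccc(Cl)cc1` carries 3,4-dichlorophenyl in place of 2,5-difluorophenyl on a carbonyl carbon. The rest of the structure stays the same.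

For the measured compounds named here, one measured step bears on this change, as it falls at the same place: an at least 1.8-fold lower number from compound 1 to compound 2 (0.26 log units; that floor lies within the scatter). On these data alone, its floor lies within the scatter, and the true size remains open because one end of the step is a limit. It also involves a different pair of groups, so it is weak guidance.

On the basis of that step, no shift beyond the scatter is expected in this assay, and no direction is favoured. The estimated change is a 1.1-fold lower number from compound 2 to compound 3 (0.03 log units; within the scatter). For compound 3 the expected value is 50000 nM, with an estimated range of 22000 nM to 100000 nM. A result reported only as a limit also remains possible.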

Compound 3, half-maximal cytotoxic concentration: 35000 nM
Compound 3: the middle estimate sits 1.4-fold (0.15 log units) above what was measured, within the range that was stated.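

In this assay, exchanging one dihalogenated phenyl for another on the carbonyl carbon gives a 1.5-fold lower number from compound 2 to compound 3 (0.19 log units; within the scatter), so 2,5-difluorophenyl and 3,4-dichlorophenyl are not told apart at this position. Among the compounds shown here, replacing 4-nitrophenyl with 3,4-dichlorophenyl at the same place gives an at least 2.8-fold lower number from compound 1 to compound 3 (0.45 log units; beyond the scatter), the first step at this position to clear the scatter, whereas the floor of the step from 4-nitrophenyl to 2,5-difluorophenyl stayed within it. On these data alone, compound 1 stands at a limit of the assay and not a number, so this step fixes only a floor and its true size stays open: the limit of > 100000 nM in this assay, at which 1 of the 3 values shown sits.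

Whether an amine, a carboxylic acid or a longer alkyl chain on this carbonyl carbon would shift the number in this assay remains open, since all three groups shown are substituted phenyls. As far as these compounds go, the shared core is the same in all three compounds, so it is also open whether a change elsewhere in the structure would matter as much as the change at this position.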